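The source may report more compounds than this note shows. Statements on the series, on what has been measured and on what is new or still open speak of the compounds shown alone.

Compound 1, `Cc1nc2c(OCc3ccccc3)cccn2c1C(N)=O`: 42% in a functional assay on the whole organism with Rattus norvegicus as the target, with a stated time of 4 h, at a dose of 40 mg/kg by the intraperitoneal route; a higher number here means more inhibition at the dose given (going by the name of the read-out), a lower number less inhibition
Compound 2, `CCSCc1c(C)nc2c(OCc3ccccc3)cccn12`: 36% in this assay
Compound 3, `Cc1nc2c(OCc3ccccc3)cccn2c1C[S+](C)[O-]`: 0% in this assay

Compound 3 stands lowest of the three numbers in this assay; the steps into it, a number 36 percentage points lower from compound 2 to compound 3 (beyond the scatter) and a number 42 percentage points lower from compound 1 to compound 3 (beyond the scatter), were both large, while the step between the two other compounds, a number 6 percentage points lower from compound 1 to compound 2 (within the scatter), lay within the scatter. Compound 4, `Cc1nc2c(OCc3ccccc3)cccn2c1CC(=O)O`, differs from compound 3 by a group of 3 heavy atoms (1 carbon, 2 oxygen; no ring) in place of a group of 3 heavy atoms (1 carbon, 1 oxygen, 1 sulfur; no ring), on a saturated chain carbon bound to an aromatic carbon. Among the compounds with values here, the one step at the same saturated chain carbon, a number 36 percentage points lower from compound 2 to compound 3 (beyond the scatter), was large, so a change at that place can move the read-out strongly in this assay. Within the data shown here, no measured step tells which way the carboxy group goes. Compound 4 is therefore expected near 18%, in a wide range from 0% to 45%. The expected step is a number 18 percentage points higher from compound 3 to compound 4 (beyond the scatter), upward but uncertain.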

Compound 4, a percentage reported as inhibition, in the whole organism at one dose (the size of the read-out at that dose, not a potency): 12%
Beside the measured number, compound 4's estimate is 6 percentage points above it; measured number inside the range.
By their numbers in this assay, from the lowest: compound 3; then compound 4; then compounds 2 and 1 (each within the scatter of the next).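

In this assay the carboxy group on the saturated chain carbon bound to an aromatic carbon gives only a partial return, with a number 12 percentage points higher from compound 3 to compound 4 (beyond the scatter) and yet a number 24 percentage points lower from compound 2 to compound 4 (beyond the scatter). This place therefore gives a graded read-out, not an all-or-none one, with the carboxy group lying between ethylsulfanyl and the group of compound 3. The carboxymethyl group also falls short of carbamoyl on the aromatic carbon, with a number 30 percentage points lower from compound 1 to compound 4 (beyond the scatter). Nothing available explains these differences. As far as these compounds go, whether an amine, a methyl ester or a longer chain at this carbon would come closer to ethylsulfanyl remains open.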